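The compounds below may be only part of what the source reports. "The series", "measured", "known", "first", "only" and "open" are said of these compounds alone.

Measured so far:
compound 1 `C#CCNC1CCc2c(SCc3ccc(Cl)cc3Cl)cccc21` — 22300 nM
compound 2 `C#CCNC1CCc2c(SCc3cccc(C)c3)cccc21` — > 100000 nM

In an ADME assay on isolated protein for inhibition of Amine oxidase [flavin-containing] B (Homo sapiens) (a higher number here means a weaker inhibitor, a lower number a stronger inhibitor), compound 1 gives 22300 nM. For compound 2 this assay reports no number, only a limit, > 100000 nM. That reading is the one described as the limit of > 100000 nM in this assay, at which 1 of the 2 values shown sits, so compound 2 stands at the weak end of what this assay can return, and the gap between compound 2 and compound 1 cannot be sized from these two readings; it may be small or large.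

Compound 3, `C#CCNC1CCc2c(SCc3cccc(Br)c3)cccc21`, has not yet been measured in this assay. It differs from compound 2 by bromo in place of methyl on an aromatic carbon. Going by the values given here, no measured pair shows this exchange, so there is nothing here to size its effect. The expectation is a modest shift toward stronger inhibition, possibly not beyond the scatter, with a real chance that this assay again reports only a limit. Compound 3 is therefore estimated at 60000 nM, within 20000 nM to 200000 nM. This estimate means an expected step of an at least 1.6-fold lower number from compound 2 to compound 3 (0.22 log units; that floor lies within the scatter).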

Compound 3, half-maximal inhibitory concentration: > 100000 nM
Compound 3 gave a limit, no number (the forecaster's own chance of this, stated with the estimate: 45%); at least 1.6-fold (0.22 log units) between middle value and limit.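

In this assay compound 3 gives > 100000 nM, a limit. Going by these compounds alone, compound 2 and compound 3 thus both stand at a limit, and no step between them can be read: the limit of > 100000 nM in this assay, at which 2 of the 3 values shown sit. On these data alone, whether bromo in place of methyl on this aromatic carbon changes inhibition at all remains open.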